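Cytotoxicity on a shared core: from methylsulfanyl to trifluoromethoxy

The source may hold more compounds than are shown below. What is called first, only, known or untested is meant among the compounds shown, and "the series" means these compounds.

Compound 1, `COc1ccc(-n2cc(CNCCN3CCN(C)CC3)c(-c3ccccc3C)n2)cc1`: > 20000 nM
Compound 2, `CSc1ccc(-n2cc(CNCCN3CCN(C)CC3)c(-c3ccccc3C)n2)cc1`: 17000 nM

Two compounds carry the measured numbers in an ADME assay on Huh-7 cells (Homo sapiens) for cytotoxicity; on this read-out lower numbers stand for higher toxicity in this test and higher numbers for lower toxicity in this test. For compound 1 the value is a limit of the assay, as the evidence of the limit of > 20000 nM in this assay, at which 1 of the 2 values shown sits, records. Compound 2 gives the only number shown, and the move an at least 1.1-fold lower number from compound 1 to compound 2 (0.07 log units; that floor lies within the scatter) is the one measured step. Compound 3, `Cc1ccccc1-c1nn(-c2ccc(OC(F)(F)F)cc2)cc1CNCCN1CCN(C)CC1`, has not been tested yet. It differs from compound 2 by trifluoromethoxy in place of methylsulfanyl on an aromatic carbon. Going by the values given here, the single step that bears on this change, from methoxy to methylsulfanyl, stayed within the scatter, so no effect beyond the scatter is expected from the further exchange to trifluoromethoxy in this assay. Compound 3 is therefore estimated at 18000 nM, in a range from 8000 nM to 40000 nM, which means an expected step of a 1.1-fold higher number from compound 2 to compound 3 (0.02 log units; within the scatter).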

Compound 3, half-maximal cytotoxic concentration: 17000 nM
For compound 3 the middle estimate is 1.1-fold (0.02 log units) above the measured one, within the range that was stated.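

In this assay, a third group at this position now shows that a larger exchange also leaves the read-out in place: trifluoromethoxy in place of methylsulfanyl raises the count of heavy atoms from 2 to 5 and gives no change at the digits printed from compound 2 to compound 3 (within the scatter). Going by these compounds alone, the exchange of trifluoromethyl for methyl on the oxygen, seen here for the first time, gives an at least 1.1-fold lower number from compound 1 to compound 3 (0.07 log units; that floor lies within the scatter), and this is only a floor. Compound 1 carries a limit of the assay and not a number: the limit of > 20000 nM in this assay, at which 1 of the 3 values shown sits.

So far, the sulfur-linked and oxygen-linked groups at this position cannot be told apart on this read-out, and how far compound 1 truly lies from compound 3 remains unknown. On these data alone, whether an amine or a carboxylic acid on the same aromatic carbon would give a step beyond the scatter stays open.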